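This account rests on a few compounds, and the source may have more. Where it says the series, first, only, none or still open, it means among the compounds named here.

Going by these compounds, compound 1 `CCCNC(=O)[C@@H]1C[C@H]2CCC[C@@H](C1)[C@@H]2NC(=O)c1cc2scnc2n1Cc1ccc(OC)cc1` is tested in an ADME assay on HEK-293T cells (Homo sapiens) for cytotoxicity, read by luminescence and CellTiter-Glo, with a stated time of 24 h (a lower number here means that less compound is tolerated, a higher number that more compound is tolerated), and gives > 25000 nM as a limit, not a number, so its true position is unknown. Two other compounds, each carrying a bromo group on a different core, also give only limits. Compound 2 `COc1ccc(Cn2c(C(=O)N3CCC(C(=O)NC(C)C)CC3)cc3sc(Br)cc32)cc1` gives > 100000 nM; > 100000 nM; > 100000 nM (3 entries) as a limit in each of its entries. Compound 3 `CCCNC(=O)C1CN(C(=O)c2cc3sc(Br)cc3n2Cc2ccc(OC)cc2)C1` gives > 100000 nM as a limit. Among the measured compounds shown here, no measured pair differs in one place alone, so no step can be read directly.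

Compound 4 `CCCNC(=O)[C@@H]1C[C@H]2CCC[C@@H](C1)[C@@H]2NC(=O)c1cc2sc(Br)nc2n1Cc1ccc(OC)cc1` keeps the core of compound 1 and differs in a single place: bromo in place of hydrogen on an aromatic carbon on an aromatic carbon, next to the ring nitrogen and next to the ring sulfur. Compound 3, which bears a bromo group and still gives > 100000 nM as a limit, supports the expectation of no step beyond the scatter in this assay in either direction. The expected change, a step that the limit leaves unreadable from compound 1 to compound 4, is an estimate and stays within that scatter. For compound 4 the estimated value is 45000 nM with an expected range from 15000 nM to 100000 nM as its bounds. The reading may well again be only a limit.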

Compound 4, half-maximal cytotoxic concentration: > 100000 nM
Compound 4: no number, only a limit; the forecaster's own chance of this, stated with the estimate: 85%; at least 2.2-fold (0.34 log units) between middle value and limit.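

In this assay compound 4 gives > 100000 nM, which is a limit. Compound 1 also gives only a limit, > 25000 nM, so no step can be read between compound 1 and compound 4. The compounds shown leave open where any true half-maximal cytotoxic concentration lies, and whether bromo in place of hydrogen changes it at all.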